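The source may hold more compounds than are shown below. What is called first, only, known or untested is meant among the compounds shown, and "the series" means these compounds.

Working notes on the series. Compound 1 `O=C1CCC(CCN2CC(N3CCC(O)CC3)C2)(c2ccc(Cl)c(Cl)c2)CN1Cc1ccccc1` gives 0.0794 nM in an assay on isolated protein (artery, Oryctolagus cuniculus) with Substance-P receptor (Homo sapiens) as the target; on this read-out higher numbers stand for weaker binding and lower numbers for tighter binding. Moving the hydroxyl group, as in compound 2 `O=C1CCC(CCN2CC(N3CCCC(O)C3)C2)(c2ccc(Cl)c(Cl)c2)CN1Cc1ccccc1` with 2 nM, produced a 25-fold higher number from compound 1 to compound 2 (1.40 log units; beyond the scatter). Compound 3 `NC1CCN(C2CN(CCC3(c4ccc(Cl)c(Cl)c4)CCC(=O)N(CC4CC4)C3)C2)CC1` gives 2 nM and stands level with compound 2 at the digits shown, the two together at the high end of the three numbers, with compound 1 the furthest away. Compound 4 `O=C1CCN(C2CN(CCC3(c4ccc(Cl)c(Cl)c4)CCC(=O)N(CC4CC4)C3)C2)CC1` differs from compound 3 by 4-oxopiperidin-1-yl in place of 4-aminopiperidin-1-yl on a saturated ring carbon. For the measured compounds named here, no measured step matches this exchange; the only step seen, from compound 1 to compound 2, concerns the hydroxyl position on the same distal ring and shows that this ring is sensitive to change. Compound 4 is therefore expected near compound 3 with wide uncertainty, a 1.5-fold higher number from compound 3 to compound 4 (0.18 log units; within the scatter), giving an estimate of 3 nM with a range of 0.6 nM to 15 nM.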

Compound 4, dissociation constant: 1.26 nM
Compound 4: middle estimate off by 2.4-fold (0.38 log units), on the high side; low and high end bracket the measured number.
By their numbers in this assay, from the lowest: compound 1; then compounds 4, 2 and 3 (each within the scatter of the next).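

In this assay, the exchange gives a 1.6-fold lower number from compound 3 to compound 4 (0.20 log units; within the scatter). At this position on the four-membered ring, an amine-bearing and a ketone-bearing piperidine therefore cannot be told apart, although the enters group has no hydrogen-bond donor, and a large step at this site is not a general outcome of changing the piperidine substituent. Nothing available explains this result. Open, on these data alone, is how a piperidine bearing a carboxylic acid or a longer aminoethyl chain would read at this position.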